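From fluoro to methoxy on the phenyl group

This account rests on a few compounds, and the source may have more. Where it says the series, first, only, none or still open, it means among the compounds named here.

Measured in a functional assay on MCF7 cells (Homo sapiens) for inhibition, read by MTT assay, with a stated time of 48 h; a lower number here means a stronger inhibitor of growth, a higher number a weaker inhibitor of growth:
- compound 1 `Cn1cc(C2CC(c3ccccc3)=NN2C(=O)c2cccnc2)c2ccccc21` gives 7200 nM
- compound 2 `Cn1cc(C2CC(c3ccccc3)=NN2C(=O)c2ccc(Cl)nc2)c2ccccc21` gives 9250 nM
- compound 3 `Cn1cc(C2CC(c3ccc(F)cc3)=NN2C(=O)c2cccnc2)c2cc(Br)ccc21` gives 480 nM

Compound 3 has the lowest number of the three, and compound 1 and compound 2 both lie above it, beyond the scatter. Compound 4 `COc1ccc(C2=NN(C(=O)c3cccnc3)C(c3cn(C)c4ccc(Br)cc34)C2)cc1` differs from compound 3 in one place: methoxy in place of fluoro on an aromatic carbon. This is methoxy in place of fluoro on an aromatic carbon. Among the compounds with values here, no measured step covers this exchange. The only one, a 1.3-fold higher number from compound 1 to compound 2 (0.11 log units; within the scatter), is chloro in place of hydrogen elsewhere in the molecule, so it offers little guidance. No step beyond the scatter is therefore expected in this assay. The expected step is a 1.3-fold higher number from compound 3 to compound 4 (0.10 log units; within the scatter). Compound 4 is estimated at 600 nM, with an expected range from 200 nM to 1800 nM.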

Compound 4, concentration for 50% growth inhibition: 1560 nM
Estimate against measurement, compound 4: 2.6-fold (0.41 log units) below, and the stated range covers the measured number.
By their numbers in this assay, from the lowest: compound 3; then compound 4; then compounds 1 and 2 (each within the scatter of the next).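

In this assay, within the data shown here, this position on the phenyl group, para to a large group, responds to a single exchange: 4-fluorophenyl to 4-methoxyphenyl gives a 3.3-fold higher number from compound 3 to compound 4 (0.51 log units; beyond the scatter), whereas the only earlier step stayed within the scatter. The exchange therefore carries a modest cost in this series, seen here in one pair only. No available measurement bears on why the number rises.

On these data alone, whether an amine, a carboxylic acid or a longer alkoxy chain at this position would lie nearer compound 3 or compound 4 stays open. So does whether the same exchange gives a similar step without the bromo group on the shared core.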